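The source may hold more compounds than are shown below. What is called first, only, known or untested is meant among the compounds shown, and "the series" means these compounds.

In an ADME assay on MDCK cells (Canis lupus familiaris) for cytotoxicity, read by MTT assay, with a stated time of 24 h (a lower number here means that less compound is tolerated, a higher number that more compound is tolerated), compound 1 (`N#CCCN(Cc1cccs1)S(=O)(=O)c1ccccc1F`) gives > 205000 nM as a limit of the assay, not a number. Compound 2 (`N#CCCN(Cc1cccs1)S(=O)(=O)c1cccc(F)c1`) gives > 205000 nM as a limit too. That leaves it with only a limit to stand on (the limit of > 205000 nM in this assay, at which 2 of the 2 values shown sit). Compound 3 (`N#CCCN(Cc1cccs1)S(=O)(=O)c1ccc(F)cc1`) carries 4-fluorophenyl in place of 3-fluorophenyl on a sulfonyl sulfur. For the measured compounds named here, with a step that the two limits leave unreadable from compound 1 to compound 2 as the only measured guide, no step beyond the scatter is expected in this assay in either direction. The expected outcome is a number no higher from compound 2 to compound 3 (the limit leaves the size open) as an estimate only. For compound 3 the estimated value is 205000 nM with an expected range from 120000 nM to 350000 nM in this assay.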

Compound 3, half-maximal cytotoxic concentration: > 205000 nM
Compound 3 gave a limit, no number (the forecaster's own chance of this, stated with the estimate: 85%); the middle value lies on the limit itself.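

In this assay no step can be read among compound 1, compound 2 and compound 3: each gives only a limit of the assay, not a number. As far as these compounds go, whether 2-fluorophenyl, 3-fluorophenyl and 4-fluorophenyl differ at all, and at what concentration, if any, these compounds harm the cells, stays open.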